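This account rests on a few compounds, and the source may have more. Where it says the series, first, only, none or still open, it means among the compounds named here.

Two compounds of a shared core carry an amine-bearing ring joined through a carbonyl and a two-carbon link to the core, and differ only in the methoxy groups on the far aromatic ring. Compound 1 `COc1ccc(-c2cc(/C=C/C(=O)c3ccc(N)cc3)[nH]n2)cc1` bears one methoxy; in a functional assay on OVCAR-3 cells (Homo sapiens) for cytotoxicity, read by sulforhodamine B assay, with a stated time of 48 h, tested at 0.01 uM (a lower number here means a stronger effect, a higher number a weaker effect of the compound at the concentration tested), compound 1 gives 104%. Compound 2 `COc1cc(-c2cc(/C=C/C(=O)c3ccc(N)cc3)[nH]n2)cc(OC)c1OC` bears three; in this assay compound 2 gives 101%. On these two numbers compound 2 sits together with compound 1, the gap between them lying within the scatter, so neither can be called the more active. Compound 3 `COc1ccc(-c2cc(/C=C/C(=O)c3ccc(N)cc3)[nH]n2)cc1OC`, not yet measured, is reached from compound 2 by the change (hydrogen in place of methoxy on an aromatic carbon). Going by the values given here, since no measured pair shows such a step, the expected step of no change at the digits printed from compound 2 to compound 3 (within the scatter) is taken as none beyond the scatter. Compound 3 is therefore estimated at 101%, within 90% to 112%.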

Compound 3, a percentage reported as activity, at one concentration (the size of the read-out at that concentration, not a potency): 106%
Estimate against measurement, compound 3: 5 percentage points below; the range from low to high includes it.
By their numbers in this assay, from the lowest: compounds 2, 1 and 3 (each within the scatter of the next).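

In this assay, the swap of hydrogen for methoxy on this aromatic carbon, ortho to a methoxy group, can now be read directly as a number 5 percentage points higher from compound 2 to compound 3 (within the scatter). The opposite kind of swap, methoxy in place of hydrogen on an aromatic carbon, can also be read, as a number 2 percentage points higher from compound 1 to compound 3 (within the scatter), so neither step separates the compounds at this single concentration. Nothing available gives a reason for these numbers.

As far as these compounds go, it remains open whether a different group on this aromatic carbon, such as a hydroxyl group, a fluorine atom or an amine, would give a number outside the scatter. The compounds shown also leave open whether the methoxy groups on this ring matter at any other concentration, since all three are compared at just one.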